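The source may report more compounds than this note shows. Statements on the series, on what has been measured and on what is new or still open speak of the compounds shown alone.

In an in vitro assay on CHOK cells for displacement of a labelled ligand from growth hormone secretagogue receptor type 1 (Homo sapiens) (a higher number here means a weaker inhibitor, a lower number a stronger inhibitor), compound 1 `CCc1nc(N)nc(N)c1-c1ccc(NCc2ccc([N+](=O)[O-])cc2)cc1` gives 11 nM. Compound 2 `CCc1nc(N)nc(N)c1-c1ccc(NCc2ccnc(Cl)c2)cc1` carries a 2-chloropyridin-4-yl in place of the 4-nitrophenyl on the saturated chain carbon bound to a nitrogen on the aromatic ring, and in this assay compound 2 gives 110 nM; the step is a 10-fold higher number from compound 1 to compound 2 (1.00 log units; beyond the scatter). Compound 3 `Nc1nc(N)c(-c2ccc(NCc3ccnc(Cl)c3)cc2)c(COCc2ccccc2)n1` keeps that 2-chloropyridin-4-yl and carries benzyloxy in place of methyl on the saturated chain carbon bound to an aromatic carbon; in this assay compound 3 gives 1.5 nM, and the step is a 73-fold lower number from compound 2 to compound 3 (1.87 log units; beyond the scatter). Compound 3 thus stands lowest of the three numbers, with compound 1 nearest and compound 2 furthest, both gaps beyond the scatter.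

Compound 4 `Nc1nc(N)c(-c2ccc(NCc3ccncc3)cc2)c(COCc2ccccc2)n1` differs from compound 3 by hydrogen in place of chloro on an aromatic carbon. No measured step touches this position: the two steps shown exchange the whole ring on the arylmethyl part or the group on the shared core, and neither removes only the chloro from the pyridine. The step from compound 1 to compound 2 exchanged the entire ring there, and the loss of the chloro alone is expected to move the number less than that exchange did. The expectation for compound 4 is a small step, if any, toward a higher number: a 1.7-fold higher number from compound 3 to compound 4 (0.22 log units; within the scatter). Compound 4 is therefore estimated at 2.5 nM, with a range from 0.8 nM to 8 nM.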

Compound 4, half-maximal inhibitory concentration: 21 nM
Beside the measured number, compound 4's estimate is 8.4-fold (0.92 log units) below it, outside the stated range (above it).
By their numbers in this assay, from the lowest: compound 3; then compounds 1 and 4 (each within the scatter of the next); then compound 2.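

In this assay, the chloro next to the ring nitrogen proves to matter on its own: with hydrogen in its place, and 1 heavy atom gone, the result is a 14-fold higher number from compound 3 to compound 4 (1.15 log units; beyond the scatter), a large step. The earlier ring exchange, a 10-fold higher number from compound 1 to compound 2 (1.00 log units; beyond the scatter), replaced the whole ring on the arylmethyl part and could not separate the contribution of the chloro from that of the rest of the ring; the step from compound 3 to compound 4 isolates that single position and shows that the 2-chloropyridin-4-yl is not interchangeable with the pyridin-4-yl in this series. No measurement at hand accounts for the size of this step, so the finding stands as an observation only.

On these data alone, it remains open whether the number at this aromatic carbon depends on chloro specifically, or whether bromo, methyl, methoxy or an amine in the same place would give a similar result. As far as these compounds go, it also remains open whether the same change gives a step of similar size on the core of compound 2, which has methyl where compound 3 has benzyloxy.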